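Phenylsulfonyl for Aminobenzoyl on the Cyanoguanidine Side Chain

The compounds below may be only part of what the source reports. "The series", "measured", "known", "first", "only" and "open" are said of these compounds alone.

Compound 1 `N#CN/C(=N\CCNC(=O)c1cccc(N)c1)NCCCOc1cccc(CN2CCCCC2)c1`: 7.29
Compound 2 `CC(C)(C)OC(=O)Nc1ccc(C(=O)NCC/N=C(\NC#N)NCCCOc2cccc(CN3CCCCC3)c2)cc1`: 6.87

Of the compounds shown here, two sharing one core have been measured in a functional assay on cardiac atrium for antagonist activity at histamine H2 receptor (Cavia porcellus); a lower number here means a less potent compound, a higher number a more potent compound, by a factor of ten per unit of this negative logarithm. Compound 1 gives 7.29 and stands highest of the two numbers. Compound 2 gives 6.87 in this assay, a number lower than that of compound 1 and by a margin beyond the usual scatter. The two differ in more than one place, so what they show about any single change is not separable.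

Compound 3 `N#CN/C(=N\CCNS(=O)(=O)c1ccccc1)NCCCOc1cccc(CN2CCCCC2)c1` has not yet been measured. It differs from compound 1 in one place: phenylsulfonyl in place of (3-aminophenyl)carbonyl on an amine nitrogen. For the measured compounds named here, no measured pair shows this change on this core, so there is nothing in the data to say whether it is favourable or not. The change exchanges one amide for a sulfonamide at the same amine nitrogen and removes the ring amine that compound 1 carries.

Given the strength of compound 1 at 7.29 and the absence of any measured precedent for this swap, compound 3 is expected to land a little lower, with a step from compound 1 to compound 3 of a number 0.39 log units lower from compound 1 to compound 3 (beyond the scatter), roughly at the edge of the scatter. The estimate for compound 3 in this assay is 6.9, within a range from 6.3 to 7.5.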

Compound 3, negative logarithm of the antagonist equilibrium constant: 6.67
Estimate against measurement, compound 3: 0.23 log units above, within the range that was stated.
By their numbers in this assay, from the lowest: compounds 3 and 2 (each within the scatter of the next); then compound 1.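

In this assay, for the compounds shown here, replacing (3-aminophenyl)carbonyl with phenylsulfonyl on the amine nitrogen gives a number 0.62 log units lower from compound 1 to compound 3 (beyond the scatter), the first step on the shared core that can be read as a single change. The step is beyond the scatter but modest, so this position does not demand the (3-aminophenyl)carbonyl group, and potency is lost without vanishing: compound 3 still gives 6.67 in this assay. Nothing measured here accounts for the size of this step.

The step combines two differences, since the carbonyl gives way to a sulfonyl and the ring amine disappears with it, and the compounds shown cannot say how much of the loss belongs to either one. A (3-aminophenyl)sulfonyl group or a plain phenylcarbonyl group on the same nitrogen would separate the two, while a longer chain between that nitrogen and the aromatic ring would show whether the spacing of the ring matters at this position.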